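Flipping One Stereocentre on the Shared Core

This account rests on a few compounds, and the source may have more. Where it says the series, first, only, none or still open, it means among the compounds named here.

Three compounds share a core and differ in the group on the amide nitrogen. Compound 1 `CCOC(=O)[C@]1(C(=O)Nc2ccccc2)C[C@H]1c1cc(OC)c(OC)c(OC)c1` gives > 100000 nM in a functional assay on QGY cells (Homo sapiens) for cytotoxicity, read by MTT assay, with a stated time of 48 h (a higher number here means a weaker inhibitor, a lower number a stronger inhibitor), which is a limit of the assay rather than a number. Compound 2 `CCOC(=O)[C@]1(C(=O)NCc2ccc(C)cc2)C[C@H]1c1cc(OC)c(OC)c(OC)c1` gives 32100 nM in this assay, and compound 3 `CCOC(=O)[C@]1(C(=O)Nc2ccccc2Cl)C[C@H]1c1cc(OC)c(OC)c(OC)c1` gives 28000 nM; the step of a 1.1-fold lower number from compound 2 to compound 3 (0.06 log units; within the scatter) means compound 2 and compound 3 cannot be told apart on these numbers.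

Compound 4 `CCOC(=O)[C@]1(C(=O)NCc2ccc(C)cc2)C[C@@H]1c1cc(OC)c(OC)c(OC)c1` differs from compound 2 only in configuration: the two compounds have the same atoms and bonds and differ only in configuration as drawn: 1 of 2 stereo elements differ; a stereocentre at a saturated ring carbon is drawn S in compound 2 and R in compound 4. For the measured compounds named here, none of the measured steps changes a stereocentre, so no measured step bears on this change, and no direction beyond the scatter can be expected. Compound 4 is therefore estimated at 40000 nM in this assay, within 10000 nM to 150000 nM, an expected step of a 1.2-fold higher number from compound 2 to compound 4 (0.10 log units; within the scatter).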

Compound 4, half-maximal inhibitory concentration: > 100000 nM
Compound 4 gave a limit, no number (the forecaster's own chance of this, stated with the estimate: 30%); middle value at least 2.5-fold (0.39 log units) from the limit.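

In this assay, for the compounds shown here, the change from S to R at this saturated ring carbon gives an at least 3.1-fold higher number from compound 2 to compound 4 (0.49 log units; beyond the scatter) even though no atom or bond changes, something no earlier step could show. Compound 4 gives > 100000 nM as a limit of the assay, not a number. The drop in activity can be traced to this stereocentre alone, because of one fact: the fact that compounds 2 and 4 differ only in the configuration as drawn

From the compounds shown here alone, whether the same change weakens compound 3 in the same way remains open, as does the role of the other stereocentre. Also open, going by these compounds, is how a carboxylic acid in place of the ethyl ester would behave in either configuration.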